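The compounds below may be only part of what the source reports. "The series", "measured", "known", "first", "only" and "open" are said of these compounds alone.

Measured compounds:
compound 1 `COc1cc(CC(O)(COCc2ccccc2)COCc2ccccc2)nc(OC)n1`, > 100000 nM
compound 2 `O=c1cc(CC(O)(COCc2ccccc2)COCc2ccccc2)[nH]c(=O)[nH]1`, > 100000 nM
compound 3 `COc1cc(CC(COCc2ccccc2)COCc2ccccc2)nc(OC)n1`, 3500 nM

In a functional assay on HeLa cells (Homo sapiens) for antiproliferative activity, read by MTT assay, with a stated time of 72 h (on this read-out higher numbers stand for weaker inhibition and lower numbers for stronger inhibition), compound 1 gives only a limit of the assay, > 100000 nM. Compound 2 likewise gives only a limit, > 100000 nM. Among the measured compounds shown here, compound 3 is the one compound with a number, 3500 nM; it differs from compound 1 by hydrogen in place of hydroxy on a saturated chain carbon bound to three saturated chain carbons, a step of an at least 28-fold lower number from compound 1 to compound 3 (1.45 log units; beyond the scatter). Compound 4 `O=c1cc(CC(COCc2ccccc2)COCc2ccccc2)[nH]c(=O)[nH]1` is not yet measured. It differs from compound 3 by a group of 8 heavy atoms (4 carbon, 2 nitrogen, 2 oxygen; one six-membered aromatic ring with 2 hetero atoms) in place of a group of 10 heavy atoms (6 carbon, 2 nitrogen, 2 oxygen; one six-membered aromatic ring with 2 hetero atoms), on a saturated chain carbon, three bonds along the chain from two oxygens on a saturated carbon. The same kind of change separates compound 1 from compound 2, (a group of 8 heavy atoms (4 carbon, 2 nitrogen, 2 oxygen; one six-membered aromatic ring with 2 hetero atoms) in place of a group of 10 heavy atoms (6 carbon, 2 nitrogen, 2 oxygen; one six-membered aromatic ring with 2 hetero atoms), on a saturated chain carbon, two bonds along the chain from an oxygen on a saturated carbon), but the surroundings differ: two bonds along the chain from an oxygen on a saturated carbon there, three bonds along the chain from two oxygens on a saturated carbon here. That earlier step, a step that the two limits leave unreadable from compound 1 to compound 2, is unreadable, since both sit at the limit of > 100000 nM in this assay, at which 2 of the 3 values shown sit. The expected step to compound 4 in this assay is an 8.6-fold higher number from compound 3 to compound 4 (0.93 log units; beyond the scatter), resting only on compound 3 at 3500 nM with no readable precedent. Compound 4 is estimated at 30000 nM, between 6000 nM and 100000 nM.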

Compound 4, half-maximal inhibitory concentration: > 100000 nM
Compound 4: a limit, no number (the forecaster's own chance of this, stated with the estimate: 40%); middle value at least 3.3-fold (0.52 log units) away from the limit.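

In this assay, putting the entering group, with its 2 double bonds outside aromatic rings, in place of the 2,6-dimethoxypyrimidin-4-yl group on the core of compound 3 gives an at least 28-fold higher number from compound 3 to compound 4 (1.45 log units; beyond the scatter). Compound 4 gives > 100000 nM, which is a limit and not a number. Whether the change acts alike on the hydroxy-bearing core of compound 1 is not shown, since the steps from compound 1 to compound 2 and from compound 2 to compound 4 cannot be read: the limit of > 100000 nM in this assay, at which 3 of the 4 values shown sit.

The compounds shown leave open how the value of compound 3 would respond to ethoxy groups in place of its methoxy groups. They also leave open the effect of an amine in place of the hydrogen on the saturated chain carbon bound to three saturated chain carbons.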